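Cyclic amine in place of dimethylamino: compound 4

The source may hold more compounds than are shown below. What is called first, only, known or untested is meant among the compounds shown, and "the series" means these compounds.

Measured in an assay for inhibition of mitogen-activated protein kinase kinase kinase 14 (Homo sapiens), read by luminescence and ADP-Glo, with a stated time of 120 min, in the presence of a further agent that is not named here; a lower number here means a stronger inhibitor, a higher number a weaker inhibitor:
compound 1 `CC(O)(C#Cc1cccc(Nc2ncnc3[nH]ccc23)c1)c1nccs1` gives 1640 nM
compound 2 `CN(C)c1ccc(C#CC(C)(O)c2nccs2)cc1Nc1ncnc2[nH]ccc12` gives 22.5 nM
compound 3 `CC(O)(C#Cc1ccc(N2CC3CC2CN3)c(Nc2ncnc3[nH]ccc23)c1)c1nccs1` gives 200 nM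

Compound 2 gives the lowest number of the three; compound 3 is nearest (an 8.9-fold higher number from compound 2 to compound 3 (0.95 log units; beyond the scatter)) and compound 1 furthest (a 73-fold lower number from compound 1 to compound 2 (1.86 log units; beyond the scatter)). Compound 4 `CN1CCN(c2ccc(C#CC(C)(O)c3nccs3)cc2Nc2ncnc3[nH]ccc23)CC1` differs from compound 2 in one place: 4-methylpiperazin-1-yl in place of dimethylamino on an aromatic carbon. Within the data shown here, two steps bear on it. Putting an amine onto the bare ring of compound 1 gave the large step from compound 1 to compound 2, while exchanging dimethylamino for a larger cyclic diamine gave the modest step from compound 2 to compound 3. The change to compound 4 is of the second kind, so a modest rise in the number is expected in this assay, a 3.1-fold higher number from compound 2 to compound 4 (0.49 log units; beyond the scatter). Compound 4 is thus estimated at 70 nM, within 25 nM to 200 nM.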

Compound 4, half-maximal inhibitory concentration: 78.3 nM
Compound 4: the middle estimate sits 1.1-fold (0.05 log units) below what was measured; the measured number falls inside the stated range.
By their numbers in this assay, from the lowest: compound 2; then compound 4; then compound 3; then compound 1.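

In this assay, a cyclic amine at this position, ortho to a large group and para to a large group, keeps a large gain over hydrogen (a 21-fold lower number from compound 1 to compound 4 (1.32 log units; beyond the scatter)). It still falls short of dimethylamino (a 3.5-fold higher number from compound 2 to compound 4 (0.54 log units; beyond the scatter)). The two groups of 7 heavy atoms are also not interchangeable, with 4-methylpiperazin-1-yl ahead of the bridged diamine of compound 3 (a 2.6-fold lower number from compound 3 to compound 4 (0.41 log units; beyond the scatter)).

Going by these compounds, whether a morpholine, a pyrrolidine or a primary amine at this position would match dimethylamino remains open. No accompanying measurement accounts for these steps.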